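From cyclopropyl to 2-chlorophenyl on the shared core

The source may hold more compounds than are shown below. What is called first, only, known or untested is meant among the compounds shown, and "the series" means these compounds.

Compound 1 `COc1ccc(Nc2nc(Nc3cnn(CCCCCCC(=O)NO)c3)ncc2Cl)cc1` gives 170 nM 
Compound 2 `CNc1nc(Nc2cnn(CCCCCCC(=O)NO)c2)ncc1Cl` gives 110 nM 
Compound 3 `O=C(CCCCCCn1cc(Nc2ncc(Cl)c(NC3CC3)n2)cn1)NO` gives 150 nM 

All three values come from a functional assay on MOLT-4 cells (Homo sapiens) for antiproliferative activity, read by MTT assay, with a stated time of 48 h (on this read-out higher numbers stand for weaker inhibition and lower numbers for stronger inhibition), and cannot be told apart there. Compound 3 lies within the scatter of both other compounds, as a 1.4-fold higher number from compound 2 to compound 3 (0.13 log units; within the scatter) shows.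

Compound 4 `O=C(CCCCCCn1cc(Nc2ncc(Cl)c(Nc3ccccc3Cl)n2)cn1)NO` carries 2-chlorophenyl in place of cyclopropyl on a nitrogen on an aromatic ring and has not yet been measured. The closest evidence is the opposite kind of exchange, cyclopropyl in place of 4-methoxyphenyl, seen in a 1.1-fold lower number from compound 1 to compound 3 (0.05 log units; within the scatter). Methyl in place of 4-methoxyphenyl gave a 1.5-fold lower number from compound 1 to compound 2 (0.19 log units; within the scatter). For the measured compounds named here, both steps stayed within the scatter, although no compound with 2-chlorophenyl has a measured value. No change beyond the scatter is therefore expected in this assay, and no direction can be favoured. The expected size of the step is no change at the digits printed from compound 3 to compound 4 (within the scatter). For compound 4 the estimated value is 150 nM, with an expected range from 70 nM to 320 nM.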

Compound 4, half-maximal inhibitory concentration: 510 nM
Compound 4: the middle estimate sits 3.4-fold (0.53 log units) below what was measured; measured number above the stated range.
By their numbers in this assay, from the lowest: compounds 2, 3 and 1 (each within the scatter of the next); then compound 4.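

For the compounds shown here, until now the group on a nitrogen on an aromatic ring could be exchanged freely, since methyl, cyclopropyl and 4-methoxyphenyl could not be told apart in this assay. 2-Chlorophenyl is the first group at this place to stand apart, with a 3.4-fold higher number from compound 3 to compound 4 (0.53 log units; beyond the scatter) and a 4.6-fold higher number from compound 2 to compound 4 (0.67 log units; beyond the scatter) as well as a 3.0-fold higher number from compound 1 to compound 4 (0.48 log units; beyond the scatter) on the same read-out, so a six-membered aromatic ring alone does not account for the shift, as compound 1 carries one too. Nothing available here explains the difference.

From the compounds shown here alone, it remains open whether the shift follows the chlorine itself or the place it holds on the ring. Plain phenyl and 4-chlorophenyl, which are not among the compounds shown, would separate those two readings.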